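A few compounds are considered here, and "the series" means these few. Any claim that something is new, unique, unknown or untested is made for them only; others in the source may bear on it.

Measured in an assay on CHO cells for displacement of a labelled ligand from prostaglandin D2 receptor 2 (Homo sapiens), read by scintillation counting (on this read-out higher numbers stand for weaker inhibition and lower numbers for stronger inhibition), so far:
compound 1, `CN(c1cccc(C#Cc2cc(Cl)ccc2OCC(=O)O)c1)S(C)(=O)=O`: 122 nM
compound 2, `CCCS(=O)(=O)c1cccc(C#Cc2c(Cl)cccc2OCC(=O)O)c1`: 55 nM
compound 3, `Cc1ccc(S(=O)(=O)CCO)cc1C#Cc1cc(Cl)ccc1OCC(=O)O`: 19 nM

Compound 1 stands at the highest of the three numbers, the weakest inhibition seen here; the number of compound 2 is lower by a gap beyond the scatter, and that of compound 3 lower still. Compound 4, `CS(=O)(=O)c1cccc(C#Cc2cc(Cl)ccc2OCC(=O)O)c1`, has not been measured. It differs from compound 1 in one place: methylsulfonyl in place of methyl(methylsulfonyl)amino on an aromatic carbon. Among the measured compounds shown here, no measured pair shows this exact change, but compound 2 and compound 3 each carry a sulfonyl group rather than a sulfonamide and each gives a lower number than compound 1. The expected step is therefore a 2.4-fold lower number from compound 1 to compound 4 (0.39 log units; beyond the scatter), a lowering beyond the scatter. Compound 4 is estimated at 50 nM, within 15 nM to 160 nM.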

Compound 4, inhibition constant: 15 nM
Beside the measured number, compound 4's estimate is 3.3-fold (0.52 log units) above it, and the stated range covers the measured number.
By their numbers in this assay, from the lowest: compounds 4 and 3 (each within the scatter of the next); then compound 2; then compound 1.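

In this assay, putting methylsulfonyl in place of methyl(methylsulfonyl)amino on this aromatic carbon gives an 8.1-fold lower number from compound 1 to compound 4 (0.91 log units; beyond the scatter) and so stronger inhibition. Among the compounds shown here, this pair gives the first direct reading at this position: the group with 4 heavy atoms rather than 6, without the nitrogen, is clearly favoured, although the count of hydrogen-bond acceptors stays the same. Nothing measured here explains the size of this step. Still open, as far as these compounds go, is how an amine or a carboxylic acid on this carbon would compare with methylsulfonyl.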